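Replacing an Imidazole Tail with Pyrrole on the Shared Core

The source may hold more compounds than are shown below. What is called first, only, known or untested is meant among the compounds shown, and "the series" means these compounds.

The series is built on the core of compound 1 `Cn1cc(C2=C(c3nn(CCCN4CCCCC4)c4ncccc34)C(=O)N(c3ccccn3)C2=O)c2ccccc21` and was tested in a functional assay on KB cells (Homo sapiens) for antiproliferative activity, read by MTT assay, with a stated time of 48 h; a higher number here means a weaker inhibitor, a lower number a stronger inhibitor. Compound 1 reaches only the limit of the assay, giving > 100000 nM. Compound 2 `Cn1cc(C2=C(c3nn(CCCCn4ccnc4)c4ncccc34)C(=O)NC2=O)c2ccccc21` likewise reaches only the limit, with > 100000 nM. Within the data shown here, compound 3 `Cn1cc(C2=C(c3nn(CCCCn4ccnc4)c4ncccc34)C(=O)N(c3ccccc3)C2=O)c2ccccc21` does give a number, 47300 nM, and the step of an at least 2.1-fold lower number from compound 2 to compound 3 (0.32 log units; beyond the scatter) is the single measured step in the set. Both limits sit at the same point, (the limit of > 100000 nM in this assay, at which 2 of the 3 values shown sit), so compound 2 stands no better than the least resolved members shown.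

Compound 4 `Cn1cc(C2=C(c3nn(CCCn4cccc4)c4ncccc34)C(=O)NC2=O)c2ccccc21` differs from compound 2 by 1H-pyrrol-1-yl in place of (1H-imidazol-1-yl)methyl on a saturated chain carbon, three bonds along the chain from an aromatic nitrogen. Among the measured compounds shown here, no measured step touches this chain: the only step measured, from compound 2 to compound 3, concerns the amide-type nitrogen in the ring and not the chain on the aromatic nitrogen, so it offers no guide to the size or direction of this change. The reasonable expectation is therefore no shift beyond the scatter in this assay, with compound 4 most likely remaining at or near the limit of compound 2. Compound 4 is estimated at 100000 nM, between 30000 nM and 300000 nM, meaning an expected step of a number no higher from compound 2 to compound 4 (the limit leaves the size open).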

Compound 4, half-maximal inhibitory concentration: > 100000 nM
Compound 4: only a limit was reported; the forecaster's own chance of this, stated with the estimate: 60%; the middle value sits exactly at the limit.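

In this assay compound 4 gives > 100000 nM, a limit and not a number. With compound 2 also at a limit, no step from compound 2 to compound 4 can be read: the limit of > 100000 nM in this assay, at which 3 of the 4 values shown sit.

The compounds shown leave open whether 3-(1H-pyrrol-1-yl)propyl in place of 4-(1H-imidazol-1-yl)butyl shifts activity at all.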